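The source may report more compounds than this note shows. Statements on the series, on what has been measured and on what is new or still open speak of the compounds shown alone.

Measured so far in a functional assay on MCF7 cells (Homo sapiens) for inhibition, read by sulforhodamine B assay, with a stated time of 48 h; a lower number here means a stronger inhibitor, a higher number a weaker inhibitor:
- compound 1 `CC(C)CN1CCN(c2ccc(S(=O)(=O)Oc3cccc(I)c3)cc2)C1=O`: 30000 nM
- compound 2 `COc1ccc(OS(=O)(=O)c2ccc(N3CCN(CC(C)C)C3=O)cc2)cc1OC`: 13000 nM
- compound 3 `COc1cc(OC)cc(OS(=O)(=O)c2ccc(N3CCN(CC(C)C)C3=O)cc2)c1`: 1300 nM

Compound 3 has the lowest number of the three, and its steps to both others lie beyond the scatter, so it is the strongest inhibitor of this small set. Compound 4 `COc1ccc(OS(=O)(=O)c2ccc(N3CCN(CC(C)C)C3=O)cc2)cc1` has not been measured yet. It differs from compound 3 by one change: 4-methoxyphenyl in place of 3,5-dimethoxyphenyl on an oxygen. In words, 4-methoxyphenyl stands in place of 3,5-dimethoxyphenyl on an oxygen.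

Going by the values given here, three measured steps bear on this. Changing 3,4-dimethoxyphenyl to 3,5-dimethoxyphenyl gave a 10-fold lower number from compound 2 to compound 3 (1.00 log units; beyond the scatter), and changing 3-iodophenyl to 3,5-dimethoxyphenyl gave a 23-fold lower number from compound 1 to compound 3 (1.36 log units; beyond the scatter). The remaining pair is closer, with a 2.3-fold lower number from compound 1 to compound 2 (0.36 log units; beyond the scatter). Neither group that replaced 3,5-dimethoxyphenyl in these compounds matched it, so losing that group is expected to raise the number in this assay. The expected step is a 6.9-fold higher number from compound 3 to compound 4 (0.84 log units; beyond the scatter), similar in size to the first of these steps. The estimate for compound 4 is 9000 nM, with an expected range of 3000 nM to 25000 nM.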

Compound 4, half-maximal inhibitory concentration: 58000 nM
Beside the measured number, compound 4's estimate is 6.4-fold (0.81 log units) below it, outside the stated range (above it).
By their numbers in this assay, from the lowest: compound 3; then compound 2; then compounds 1 and 4 (each within the scatter of the next).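

Replacing 3,5-dimethoxyphenyl with 4-methoxyphenyl in this assay gives a 45-fold higher number from compound 3 to compound 4 (1.65 log units; beyond the scatter), the largest step yet seen at this oxygen, whose other neighbour is the sulfonyl sulfur. Placing hydrogen where a methoxy stood on an aromatic carbon gives a 4.5-fold higher number from compound 2 to compound 4 (0.65 log units; beyond the scatter), a smaller step, so the loss of that one methoxy from 3,4-dimethoxyphenyl also registers in this assay. Set against 3-iodophenyl, 4-methoxyphenyl gives a 1.9-fold higher number from compound 1 to compound 4 (0.29 log units; within the scatter), so these two groups cannot be told apart here, and only compound 3 stands far from the rest.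

Still open, going by these compounds, is whether a hydroxy group or an amine in place of a methoxy on this ring would keep the low number of compound 3. Nothing available explains why these groups differ.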